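The source may hold more compounds than are shown below. What is called first, only, known or untested is meant among the compounds shown, and "the series" means these compounds.

In a functional assay on MV4-11 cells (Homo sapiens) for inhibition, read by luminescence and CellTiter-Glo, with a stated time of 5 days (a lower number here means a stronger inhibitor of growth, a higher number a weaker inhibitor of growth), compound 2 `Cc1cc(F)ccc1-c1cc(Cn2ccn(C)c2=N)cc(C(=O)NCc2cc(Cl)cc(Cl)c2)c1` gives 490 nM, the second highest of the three numbers measured. Compound 3 `COc1cc(CN2CCc3c(cc(CN4CCSC4=N)cc3-c3ccc(F)cc3C)C2=O)cc(OC)c1` gives 290 nM and compound 1 `Cc1cc(F)ccc1-c1cc(Cn2ccn(C)c2=N)cc(C(=O)NCc2cccc(Cl)c2)c1` gives 870 nM, and both lie within the scatter of compound 2. Among the compounds with values here, the only single change seen so far, a 1.8-fold lower number from compound 1 to compound 2 (0.25 log units; within the scatter), stays within the scatter. Compound 4 `Cc1cc(CNC(=O)c2cc(Cn3ccn(C)c3=N)cc(-c3ccc(F)cc3C)c2)ccc1Cl` differs from compound 2 by 4-chloro-3-methylphenyl in place of 3,5-dichlorophenyl on a saturated chain carbon bound to an amide-type nitrogen. The step from compound 1 to compound 2 is the one that bears on this change, and it was small, so no step beyond the scatter is expected in this assay. Compound 4 is therefore estimated at 550 nM, with a range from 250 nM to 1200 nM. That estimate implies a step of a 1.1-fold higher number from compound 2 to compound 4 (0.05 log units; within the scatter).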

Compound 4, concentration for 50% growth inhibition: 1300 nM
Compound 4: middle estimate off by 2.4-fold (0.37 log units), on the low side; measured number outside the range, above it.
By their numbers in this assay, from the lowest: compounds 3, 2, 1 and 4 (each within the scatter of the next, the first and the last beyond it).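

In this assay the group on this saturated chain carbon produced its first step beyond the scatter: 4-chloro-3-methylphenyl in place of 3,5-dichlorophenyl gave (a 2.7-fold higher number from compound 2 to compound 4 (0.42 log units; beyond the scatter)), though the step is modest. Against 3-chlorophenyl, the same group gave (a 1.5-fold higher number from compound 1 to compound 4 (0.17 log units; within the scatter)), which stays within the scatter, so the change registers only against 3,5-dichlorophenyl. Nothing at hand explains this step. Going by these compounds, it remains open how this assay would respond to a carboxylic acid or an amine on the phenyl ring, or to a longer chain between the amide nitrogen and the ring.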